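Ester Amine Replaced by tert-Butyl in the Compound 2 Series

The source may hold more compounds than are shown below. What is called first, only, known or untested is meant among the compounds shown, and "the series" means these compounds.

Compound 2 `O=C(CN1CCCCC1)OC1CC2(N3CCCC3)CC(c3ccccc3)C1C(c1ccccc1)C2` gives 14200 nM in an ADME assay on L6 cells (Rattus norvegicus) for cytotoxicity, with a stated time of 72 h (on this read-out lower numbers stand for stronger inhibition and higher numbers for weaker inhibition), the lowest of the three numbers. Compound 1 `O=C(CN1CCCC1)OC1CC2(N3CCCCC3)CC(c3ccccc3)C1C(c1ccccc1)C2` gives 16400 nM in this assay, within the scatter of compound 2. Compound 3 `CN(C)C12CC(OC(=O)CN3CCCCC3)C(C(c3ccccc3)C1)C(c1ccccc1)C2` gives 29300 nM in this assay; the step of a 2.1-fold higher number from compound 2 to compound 3 (0.31 log units; beyond the scatter) is the only one beyond the scatter, and it concerns dimethylamino in place of pyrrolidin-1-yl on a saturated ring carbon. Compound 4 `CC(C)(C)C(=O)OC1CC2(N3CCCC3)CC(c3ccccc3)C1C(c1ccccc1)C2` differs from compound 2 as follows: tert-butyl in place of (piperidin-1-yl)methyl on a carbonyl carbon. Among the compounds with values here, no measured step touches the ester side, so the direction of a 1.3-fold higher number from compound 2 to compound 4 (0.10 log units; within the scatter) is expected to be uncertain and the size kept close to the scatter. For compound 4 in this assay the estimate is 18000 nM, within 7000 nM to 45000 nM.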

Compound 4, half-maximal inhibitory concentration: 7620 nM
Estimate against measurement, compound 4: 2.4-fold (0.37 log units) above; measured number inside the range.
By their numbers in this assay, from the lowest: compounds 4, 2, 1 and 3 (each within the scatter of the next, the first and the last beyond it).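

The ester side now has a measured step: in this assay tert-butyl in place of (piperidin-1-yl)methyl on a carbonyl carbon gives a 1.9-fold lower number from compound 2 to compound 4 (0.27 log units; within the scatter) and so stays within the scatter. The ring and the nitrogen of the leaving group are therefore not needed for compound 4 to retain cytotoxicity at this level. No evidence on the cause of this step is available. Still open, going by these compounds, is whether a carboxylic acid or a longer alkyl chain on the carbonyl carbon would stay within the scatter of compound 2, and whether a morpholin-4-ylmethyl group would match (piperidin-1-yl)methyl.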